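The source may hold more compounds than are shown below. What is called first, only, known or untested is meant among the compounds shown, and "the series" means these compounds.

Within the data shown here, in an ADME assay on microsomes from liver (Rattus norvegicus) for metabolic stability, read by HPLC, with a stated time of 10 min, tested at 3 uM (a lower number here means that less of the compound is left, a higher number that more of the compound is left), compound 2 (`COc1nc(C)c(Nc2nc(Cl)cn([C@H](C)C3CC3)c2=O)cc1C`) gives 55%, the higher of the two numbers so far. Among the measured compounds shown here, the only comparison is compound 1 (`COC[C@@H](C1CC1)n1cc(Cl)nc(Nc2cc(C)c(OC)nc2C)c1=O`), which gives 13%. These two differ in one place: compound 2 has 1-cyclopropylethyl on an aromatic nitrogen, and compound 1 has 1-cyclopropyl-2-methoxyethyl there. That swap is a large step, a number 42 percentage points higher from compound 1 to compound 2 (beyond the scatter).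

Compound 3 (`COC[C@@H](C)n1cc(Cl)nc(Nc2cc(C)c(OC)nc2C)c1=O`) changes the same group of compound 2 in a different way: methoxymethyl in place of cyclopropyl on a saturated chain carbon bound to an aromatic nitrogen and a saturated chain carbon. It therefore keeps the methoxymethyl of compound 1 but has no cyclopropyl. For the measured compounds named here, the one measured step bears on this change only in part, and no measurement shows what losing cyclopropyl does on its own. Compound 1, which also carries methoxymethyl, stands at 13%, so a fall in this assay is expected, probably smaller than the measured step but still beyond the scatter. The expected step is a number 22 percentage points lower from compound 2 to compound 3 (beyond the scatter). For compound 3 the estimated value is 33%, with an expected range from 14% to 56%.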

Compound 3, percent of the compound remaining: 8%
For compound 3 the middle estimate is 25 percentage points above the measured one; measured number below the stated range.
By their numbers in this assay, from the lowest: compounds 3 and 1 (each within the scatter of the next); then compound 2.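

In this assay, among these compounds, the change of methoxymethyl in place of cyclopropyl gives a number 47 percentage points lower from compound 2 to compound 3 (beyond the scatter), so this saturated chain carbon, bound to an aromatic nitrogen and a saturated chain carbon, is sensitive to more than the one swap seen before. The other new step, with methyl in place of cyclopropyl while the methoxymethyl stays, is a number 5 percentage points lower from compound 1 to compound 3 (within the scatter), so with methoxymethyl present, the cyclopropyl makes no difference that can be told from the scatter. Across these three compounds, the two that carry methoxymethyl, compound 1 and compound 3, both sit far below compound 2, which lacks it, and no compound shown goes against this pattern.

No experimental finding is available to explain why the methoxymethyl goes with so much less compound remaining. The compounds shown leave open whether this pattern belongs to the ether oxygen or to the length of the chain, and how a hydroxymethyl, an ethyl or a plain methyl in place of the cyclopropyl of compound 2 would fare.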